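Acid for ester on the biphenyl tail of a bile acid agonist

A few compounds are considered here, and "the series" means these few. Any claim that something is new, unique, unknown or untested is made for them only; others in the source may bear on it.

Compound 1 `CCc1ccccc1-n1nc(C)c2c1NC(=O)[C@H](C)S[C@@H]2c1ccc(Oc2ccccc2)cc1` gives 1100 nM in an assay on isolated protein for agonist activity at Bile acid receptor (Homo sapiens), read by AlphaScreen, with a stated time of 30 min; on this read-out lower numbers stand for an effect already at smaller amounts and higher numbers for an effect only at larger amounts of compound. Compound 2 `COC(=O)c1cccc(-c2ccc([C@H]3S[C@@H](C)C(=O)Nc4c3c(C)nn4-c3ccccc3C)cc2)c1` carries a biphenyl with a methyl ester, and in this assay compound 2 is reported as "not active" (no number reported), with no number to place it against compound 1. Compound 3 `Cc1ccccc1-n1nc(C)c2c1NC(=O)[C@H](C)S[C@@H]2c1ccc(-c2ccc(C(=O)O)cc2)cc1` is the related structure still to be measured. It differs from compound 2 in one place: 4-carboxyphenyl in place of 3-(methoxycarbonyl)phenyl on an aromatic carbon. Among the compounds with values here, no measured pair shows the effect of this change, and compound 2 gives no number from which a step could be counted, so the direction can only be expected, not read off. The account therefore rests on compound 1, whose value in this assay shows that this core can reach a measurable effect, and on the fact that compound 2 does not. Compound 3 is expected to give a number near 800 nM, estimated within 150 nM to 5000 nM.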

Compound 3, half-maximal effective concentration: "not active" (no number reported)
Nothing numeric was reported for compound 3, and the estimate cannot be compared.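

Compound 2 and compound 3 are both reported without a number in this assay, so no step can be read between them. The compounds shown leave open what separates either from compound 1, which does give a number. Nothing shown offers an explanation for this result.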